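Furan-3-yl in Place of Phenyl on a Nucleoside Core

The compounds below may be only part of what the source reports. "The series", "measured", "known", "first", "only" and "open" are said of these compounds alone.

The study covers two measured compounds and one still to be measured. Compound 1 `COc1ncnc2c1c(-c1ccoc1)cn2[C@@H]1O[C@H](CO)[C@@H](O)[C@H]1O` gives 1160 nM in a functional assay on A549 cells (Homo sapiens), read by MTT assay, with a stated time of 72 h; on this read-out lower numbers stand for stronger inhibition and higher numbers for weaker inhibition. Compound 2 `CNc1ncnc2c1c(-c1ccccc1)cn2[C@@H]1O[C@H](CO)[C@@H](O)[C@H]1O` reaches only the limit of > 20000 nM in this assay, a limit rather than a number. Compound 2 thus sits at the limit of > 20000 nM in this assay, at which 1 of the 2 values shown sits. Compound 3 `CNc1ncnc2c1c(-c1ccoc1)cn2[C@@H]1O[C@H](CO)[C@@H](O)[C@H]1O` differs from compound 2 in one place: furan-3-yl in place of phenyl on an aromatic carbon. Within the data shown here, no measured step covers this change, so its size is open; a move toward stronger inhibition is expected, an at least 2.5-fold lower number from compound 2 to compound 3 (0.39 log units; beyond the scatter), likely beyond the scatter. Compound 3 is estimated at 8000 nM, within 2000 nM to 30000 nM.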

Compound 3, half-maximal inhibitory concentration: > 20000 nM
Compound 3 was reported as a limit; the forecaster's own chance of this, stated with the estimate: 35%; middle value at least 2.5-fold (0.39 log units) away from the limit.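

Compound 3 gives a limit rather than a number in this assay, as compound 2 does, so the step between them cannot be read and furan-3-yl in place of phenyl shows no measurable gain here. With furan-3-yl held fixed, methylamino in place of methoxy on an aromatic carbon gives an at least 17-fold higher number from compound 1 to compound 3 (1.23 log units; beyond the scatter). Most of the set now sits at the limit: the limit of > 20000 nM in this assay, at which 2 of the 3 values shown sit.

From the compounds shown here alone, it remains open whether furan-3-yl and phenyl differ at all when methoxy is present. Going by these compounds, it also remains open whether a plain amine or dimethylamino in place of methylamino would give a number rather than a limit.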